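Carbamate stereocentre inversion in a macrocycle-free protease series

A few compounds are considered here, and "the series" means these few. Any claim that something is new, unique, unknown or untested is made for them only; others in the source may bear on it.

Of the compounds shown here, two have been measured in an ADME assay on Caco-2 cells (Homo sapiens) for permeability, in the apical to basolateral direction; a lower number here means that the compound crosses the layer more slowly, a higher number that the compound crosses the layer faster. Compound 1 `CC[C@@H]1C[C@]1(NC(=O)[C@@H]1C[C@@H](Oc2cc(-c3csc(NC(C)C)n3)nc3c(Cl)c(OC)ccc23)CN1C(=O)[C@@H](NC(=O)O[C@@H]1C[C@@H]2C[C@@H]2C1)C(C)(C)C)C(=O)O` gives 7.3 10^-6 cm/s. Compound 2 `CC[C@@H]1C[C@]1(NC(=O)[C@@H]1C[C@@H](Oc2cc(-c3csc(NC(C)C)n3)nc3c(Cl)c(OC)ccc23)CN1C(=O)[C@@H](NC(=O)O[C@H]1C[C@@H]2[C@H](C1)C2(F)F)C(C)(C)C)C(=O)O` gives 4.5 10^-6 cm/s. The step of a 1.6-fold lower number from compound 1 to compound 2 (0.21 log units; within the scatter) exchanges the bicyclic carbamate substituent for its difluorinated counterpart, so compound 2 stands alongside compound 1 with no separation beyond the scatter.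

Compound 3 `CC[C@@H]1C[C@]1(NC(=O)[C@@H]1C[C@@H](Oc2cc(-c3csc(NC(C)C)n3)nc3c(Cl)c(OC)ccc23)CN1C(=O)[C@@H](NC(=O)O[C@@H]1C[C@@H]2[C@H](C1)C2(F)F)C(C)(C)C)C(=O)O` is the next candidate. The change from compound 2 to compound 3 is the two compounds have the same atoms and bonds and differ only in configuration as drawn: 1 of 8 stereo elements differ; a stereocentre at a saturated ring carbon is drawn r in compound 2 and s in compound 3. Among the compounds with values here, no measured step in this assay involves a change of configuration alone; the one measured step, the carbamate exchange from compound 1 to compound 2, stayed within the scatter. There is thus no basis for expecting a shift beyond the scatter here, and the step of no change at the digits printed from compound 2 to compound 3 (within the scatter) is the expected outcome. Compound 3 is estimated at 4.5 10^-6 cm/s in this assay, with a range from 2.3 10^-6 cm/s to 9 10^-6 cm/s.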

Compound 3, apparent permeability in the Caco-2 assay: 6.8 10^-6 cm/s
Beside the measured number, compound 3's estimate is 1.5-fold (0.18 log units) below it; low and high end bracket the measured number.
By their numbers in the Caco-2 assay, from the lowest: compounds 2, 3 and 1 (each within the scatter of the next).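

In the Caco-2 assay, the change of configuration at this saturated ring carbon gives a 1.5-fold higher number from compound 2 to compound 3 (0.18 log units; within the scatter), and the difluorinated group in place of the unfluorinated one gives a 1.1-fold lower number from compound 1 to compound 3 (0.03 log units; within the scatter), so neither change separates these compounds in this assay. The same change of configuration does separate them in a physicochemical assay for solubility, measured as thermodynamic solubility, at pH 2.2 (a higher number here means a more soluble compound, a lower number a less soluble compound), with an at least 3.3-fold lower number from compound 2 to compound 3 (0.52 log units; beyond the scatter), the only step shown beyond the scatter, and it is a change of configuration alone: the fact that compounds 2 and 3 differ only in the configuration as drawn In the physicochemical assay compound 2 gives 20000 nM. In the physicochemical assay compound 3 gives < 6000 nM, which is a limit and not a measured value: the limit of < 6000 nM in the physicochemical assay, at which 1 of the 2 values shown sits.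

On these data alone, it remains open whether configuration at this ring carbon matters in the same way with another group on this oxygen, such as a longer chain or a group carrying an amine. As far as these compounds go, the true size of the step in the physicochemical assay also remains open.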